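The source may hold more compounds than are shown below. What is called first, only, known or untested is meant among the compounds shown, and "the series" means these compounds.

Compound 1 `O=C(Nc1cccc(-n2cc(-c3ccncc3)c(-c3ccc(Cl)c(O)c3)n2)c1)Nc1ccc(Cl)c(Cl)c1` carries a urea ending in a 3,4-dichlorophenyl group; in a functional assay on TK-10 cells (Homo sapiens) for inhibition, read by sulforhodamine B assay, with a stated time of 48 h (on this read-out higher numbers stand for weaker inhibition of growth and lower numbers for stronger inhibition of growth), compound 1 gives 1910 nM. Compound 2 `COc1cc(-c2nn(-c3cccc(NC(=O)Nc4cccc(C(F)(F)F)c4)c3)cc2-c2ccncc2)ccc1Cl` gives 1310 nM, within the scatter of compound 1, so the two cannot be ordered. Compound 3 `COc1cc(-c2nn(-c3cccc(NC(=O)c4ccccc4)c3)cc2-c2ccncc2)ccc1Cl` gives 7000 nM, the highest of the three. Compound 1 thus stands second highest of the three numbers, nearest compound 2 and furthest from compound 3. Within the data shown here, the one single-point step measured, a 5.3-fold higher number from compound 2 to compound 3 (0.73 log units; beyond the scatter), concerns the carbonyl end of the chain and does not touch the exchange now in question.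

Compound 4 `O=C(Nc1cccc(-n2cc(-c3ccncc3)c(-c3ccc(Cl)c(O)c3)n2)c1)Nc1ccc(Cl)c(C(F)(F)F)c1` differs from compound 1 by trifluoromethyl in place of chloro on an aromatic carbon. Among the measured compounds shown here, no measured pair isolates this exchange; compound 2 also bears a trifluoromethyl group but differs from compound 1 in more than one place, so it gives no direct reading. With the urea and the ring kept, no step beyond the scatter is expected in this assay, in either direction. Compound 4 is therefore expected to give 1600 nM, between 600 nM and 4500 nM, an expected step of a 1.2-fold lower number from compound 1 to compound 4 (0.08 log units; within the scatter).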

Compound 4, concentration for 50% growth inhibition: 1500 nM
For compound 4 the middle estimate is 1.1-fold (0.03 log units) above the measured one; measured number inside the range.
By their numbers in this assay, from the lowest: compounds 2, 4 and 1 (each within the scatter of the next); then compound 3.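

In this assay, trifluoromethyl in place of chloro on an aromatic carbon, ortho to a chloro group, gives a step within the scatter (a 1.3-fold lower number from compound 1 to compound 4 (0.10 log units; within the scatter)), so the 3,4-dichlorophenyl and 4-chloro-3-(trifluoromethyl)phenyl ends of the urea cannot be ordered. Among these compounds, this is the first reading of a change at this end of the urea; the earlier step (a 5.3-fold higher number from compound 2 to compound 3 (0.73 log units; beyond the scatter)) was a change on a carbonyl carbon and lay beyond the scatter. No measurement offered here bears on why the two groups read alike.

On these data alone, whether an amine or a carboxylic acid in place of the trifluoromethyl would also stay within the scatter remains open. So does whether this exchange reads the same on the core of compound 2.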